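Swapping the base on a furanone nucleoside analogue

A few compounds are considered here, and "the series" means these few. Any claim that something is new, unique, unknown or untested is made for them only; others in the source may bear on it.

The shared core of compound 2 `Nc1ccn(C[C@H](O)[C@H]2OC(=O)C(OCc3ccccc3)=C2OCc2ccccc2)c(=O)n1` carries a six-membered aromatic base on a hydroxylated chain. In a functional assay on MCF7 cells (Homo sapiens) for inhibition, read by MTT assay, with a stated time of 72 h (a higher number here means a weaker inhibitor, a lower number a stronger inhibitor), compound 2 gives 7340 nM, the highest of the two numbers recorded, with compound 3 `O=C1O[C@H]([C@@H](O)Cn2ccc(NC(=O)c3ccccc3)nc2=O)C(OCc2ccccc2)=C1OCc1ccccc1` giving 4790 nM in this assay. The change from compound 2 to compound 3, a 1.5-fold lower number from compound 2 to compound 3 (0.19 log units; within the scatter), lies within the scatter, so no order between them can be claimed. Compound 1 `Nc1ncn(CCC2(N)OC(=O)C(OCc3ccccc3)=C2OCc2ccccc2)c(=O)n1` reaches only the limit of this assay, > 100000 nM, which is a limit and not a number (the limit of > 100000 nM in this assay, at which 1 of the 3 values shown sits). Compound 4 `Nc1ncn(C[C@H](O)[C@H]2OC(=O)C(OCc3ccccc3)=C2OCc2ccccc2)c(=O)n1` differs from compound 2 by a group of 8 heavy atoms (3 carbon, 4 nitrogen, 1 oxygen; one six-membered aromatic ring with 3 hetero atoms) in place of a group of 8 heavy atoms (4 carbon, 3 nitrogen, 1 oxygen; one six-membered aromatic ring with 2 hetero atoms), on a saturated chain carbon, two bonds along the chain from an oxygen on a saturated carbon and a saturated ring carbon. Among the compounds with values here, no measured step covers this exchange of the base; the only measured step, from compound 2 to compound 3, touches a different site and is within the scatter, so it carries no weight here. The group entering in compound 4 is the same base that compound 1 bears on a different chain, and compound 1 sits at the limit. Compound 4 is therefore expected to give a weaker number than compound 2, with a step of about a 2.0-fold higher number from compound 2 to compound 4 (0.31 log units; beyond the scatter), estimated at 15000 nM in this assay, with a range from 4000 nM to 60000 nM.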

Compound 4, half-maximal inhibitory concentration: 73800 nM
Estimate against measurement, compound 4: 4.9-fold (0.69 log units) below, and the stated range ends below it.
By their numbers in this assay, from the lowest: compounds 3 and 2 (each within the scatter of the next); then compound 4. At a limit, above all of these: compound 1.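

On the saturated chain carbon that carries the base, the one six-membered aromatic ring with 3 hetero atoms in place of the one with 2 hetero atoms moves the number beyond the scatter in this assay: a 10-fold higher number from compound 2 to compound 4 (1.00 log units; beyond the scatter). The benzoyl change on the base did not do so, as a 1.5-fold lower number from compound 2 to compound 3 (0.19 log units; within the scatter) stays within the scatter, so this is the only change shown at which the read-out clearly responds to the base. Compound 1, which bears the same base as compound 4 on a different chain, stands at a limit and not at a number: the limit of > 100000 nM in this assay, at which 1 of the 4 values shown sits.

The compounds shown do not tell whether a benzoyl on the amino nitrogen of compound 4 would behave as it does on compound 2. They also leave open how a methyl group or a fluorine atom on the base would read at this position.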